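Moving a methyl group: from compound 3 to compound 4

The source may hold more compounds than are shown below. What is called first, only, known or untested is meant among the compounds shown, and "the series" means these compounds.

Values in a functional assay on HCT-116 cells (Homo sapiens) for inhibition, read by MTT assay, with a stated time of 72 h; on this read-out lower numbers stand for stronger inhibition and higher numbers for weaker inhibition:
Compound 1 `COc1cc2c(Oc3ccc(NC(=O)c4nn(-c5ccccc5C)cc(C)c4=O)c(F)c3)ccnc2cc1OCCCCCCC(=O)NO` gives 2300 nM
Compound 2 `COc1cc2c(Oc3ccc(NC(=O)c4nn(-c5ccccc5C)cc(C)c4=O)cc3)ccnc2cc1OCC(=O)NO` gives 9260 nM
Compound 3 `COc1cc2c(Oc3ccc(NC(=O)c4nn(-c5ccc(C)cc5)cc(C)c4=O)cc3)ccnc2cc1OCCCCCCC(=O)NO` gives 400 nM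

Among these three, compound 3 has the lowest number, and its gap to each of the other two lies beyond the scatter of repeated measurements. The next compound to be tested is compound 4 `COc1cc2c(Oc3ccc(NC(=O)c4nn(-c5ccccc5C)cc(C)c4=O)cc3)ccnc2cc1OCCCCCCC(=O)NO`. It has the same atoms as compound 3, joined differently, with 2-methylphenyl in place of 4-methylphenyl on an aromatic nitrogen.

Among the compounds with values here, no measured pair isolates this change. Compound 1 and compound 2 both carry the 2-methylphenyl group, but each also differs from compound 4 elsewhere. Their values, compound 1 at 2300 nM and compound 2 at 9260 nM, both lie above that of compound 3, so a moderate rise in this assay is expected rather than a drop. The estimated change is a step of a 2.3-fold higher number from compound 3 to compound 4 (0.35 log units; beyond the scatter). The expected value for compound 4 is 900 nM, with an estimated range of 300 nM to 2700 nM.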

Compound 4, half-maximal inhibitory concentration: 660 nM
Estimate against measurement, compound 4: 1.4-fold (0.13 log units) above; the measured number falls inside the stated range.
By their numbers in this assay, from the lowest: compounds 3 and 4 (each within the scatter of the next); then compound 1; then compound 2.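

In this assay, moving the methyl group from 4-methylphenyl to 2-methylphenyl on the aromatic nitrogen gives a 1.7-fold higher number from compound 3 to compound 4 (0.22 log units; within the scatter), so this assay does not separate the two placements. Compound 4 also allows single-change readings within the 2-methylphenyl compounds: 5-(hydroxycarbamoyl)pentyl in place of hydroxycarbamoyl gives a 14-fold lower number from compound 2 to compound 4 (1.15 log units; beyond the scatter), and hydrogen in place of fluoro on an aromatic carbon gives a 3.5-fold lower number from compound 1 to compound 4 (0.54 log units; beyond the scatter), both larger than the methyl move and beyond the scatter. Nothing shown here explains any of these steps.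

As far as these compounds go, it remains open whether a plain phenyl group, or a chloro or methoxy group in place of the methyl on this ring, would also leave the number within the scatter of compound 3. From the compounds shown here alone, the effect of a chain of intermediate length at the hydroxamic acid end is also open.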